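From Trifluoromethyl to 1,1-Difluoroethyl on the Urea Phenyl

This account rests on a few compounds, and the source may have more. Where it says the series, first, only, none or still open, it means among the compounds named here.

Compound 1, `CNc1cc(Oc2ccc(NC(=O)Nc3cccc(C)c3)cc2)ncn1`, gives 1260 nM in an assay on isolated protein for inhibition of serine/threonine-protein kinase TNNI3K (Homo sapiens); on this read-out lower numbers stand for stronger inhibition and higher numbers for weaker inhibition.
Compound 2, `CNc1cc(Oc2ccc(NC(=O)Nc3ccccc3)cc2)ncn1`, gives 6300 nM in this assay.
Compound 3, `CNc1cc(Oc2ccc(NC(=O)Nc3cccc(C(F)(F)F)c3)cc2)ncn1`, gives 40 nM in this assay.

Compound 3 holds the lowest number of the three, and its steps to compound 1 and compound 2 both lie beyond the scatter, so it is the strongest inhibitor measured. Compound 4, `CNc1cc(Oc2ccc(NC(=O)Nc3cccc(C(C)(F)F)c3)cc2)ncn1`, differs from compound 3 by methyl in place of fluoro on a saturated chain carbon bound to an aromatic carbon and two fluorine atoms. Among the compounds with values here, two measured steps bear on this: a 32-fold lower number from compound 1 to compound 3 (1.50 log units; beyond the scatter) and a 160-fold lower number from compound 2 to compound 3 (2.20 log units; beyond the scatter). The 1,1-difluoroethyl group sits between trifluoromethyl and methyl in its fluorine count, so a modest rise in this assay is expected, smaller than the step from compound 1. Compound 4 is expected at 110 nM, ranging from 35 nM to 400 nM. That estimate means a 2.8-fold higher number from compound 3 to compound 4 (0.44 log units; beyond the scatter).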

Compound 4, half-maximal inhibitory concentration: 40 nM
For compound 4 the middle estimate is 2.8-fold (0.44 log units) above the measured one; the range from low to high includes it.
By their numbers in this assay, from the lowest: compounds 3 and 4 (each within the scatter of the next); then compound 1; then compound 2.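

In this assay methyl in place of fluoro on this carbon gives no change at the digits printed from compound 3 to compound 4 (within the scatter) and so trifluoromethyl and 1,1-difluoroethyl cannot be told apart here. Against hydrogen the 1,1-difluoroethyl group gives a 160-fold lower number from compound 2 to compound 4 (2.20 log units; beyond the scatter) and against methyl it gives a 32-fold lower number from compound 1 to compound 4 (1.50 log units; beyond the scatter) which matches what trifluoromethyl achieved. Nothing available explains why these two groups read alike.

Still open, going by these compounds, is how an amine, a methoxy group or a longer chain such as 1,1-difluoropropyl would read in this place. The compounds shown also leave open whether a carbon carrying a single fluorine would hold the same level.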